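The compounds below may be only part of what the source reports. "The series", "measured", "known", "first", "only" and "open" are said of these compounds alone.

Working notes on a bis-aziridinyl quinone series read in a functional assay on L1210 cells (Mus musculus), with a stated time of 1 days; a lower number here means a less potent compound, a higher number a more potent compound, by a factor of ten per unit of this negative logarithm.

Compound 1 `O=C1C(CCO)=C(N2CC2)C(=O)C(CCO)=C1N1CC1` gives 5.6 in this assay. Compound 2 `CC1=C(N2CC2)C(=O)C(CCCOC(N)=O)=C(N2CC2)C1=O` gives 5.48 in this assay. On these two numbers compound 2 lies within the scatter of compound 1, so nothing separates them.

Among the compounds with values here, no step between measured compounds that differ in one place is available, so the move to compound 3 `CC(=O)C1=C(N2CC2)C(=O)C(C)=C(N2CC2)C1=O` rests on the structural change alone: a group of 3 heavy atoms (2 carbon, 1 oxygen; no ring) in place of a group of 7 heavy atoms (4 carbon, 1 nitrogen, 2 oxygen; no ring), on a double-bonded ring carbon. The group that leaves carries the carbamate chain; the acetyl that enters is smaller and keeps one hydrogen-bond acceptor but no donor. Within the data shown here, with no comparable step in hand, the step from compound 2 to compound 3 is expected to be small, in either direction, or none beyond the scatter, and the estimated step of a number 0.02 log units higher from compound 2 to compound 3 (within the scatter) reflects that.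

Compound 3 is estimated at 5.5 in this assay, with a range from 4.8 to 6.2.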

Compound 3, logarithm of the reciprocal of the active concentration, log(1/C): 3.48
Estimate against measurement, compound 3: 2.02 log units above; measured number below the stated range.
By their numbers in this assay, from the lowest: compound 3; then compounds 2 and 1 (each within the scatter of the next).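

In this assay, this position on the double-bonded ring carbon does not tolerate every group: with acetyl in place of the group of 7 heavy atoms, the value falls by a large margin, a number 2.00 log units lower from compound 2 to compound 3 (beyond the scatter), beyond the scatter. Within the data shown here, compounds 1 and 2 could not show this, as they differ in more than one place and give no step at this position. The change therefore marks this position as one where the group carried matters strongly to the read-out. Nothing measured on these compounds accounts for the drop.

The compounds shown leave open whether the drop follows from the arrival of acetyl or from the loss of the longer chain. A simple amine, a carboxylic acid or a longer chain ending in a hydroxyl group at this same position, with the rest of compound 2 kept, would help separate these readings.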